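Fluoro to Hydroxy on the Aryl Group: Working Notes

The compounds below may be only part of what the source reports. "The series", "measured", "known", "first", "only" and "open" are said of these compounds alone.

Measured compounds:
compound 1, `CCOC(=O)c1cnn(-c2nc(-c3ccccc3F)c(C#N)c(=O)n2C)c1N` — 87 ug/mL
compound 2, `CSc1nc(-c2ccco2)c(C#N)c(=O)n1C` — 108 ug/mL

In a functional assay, with a stated time of 150 min (on this read-out lower numbers stand for stronger inhibition and higher numbers for weaker inhibition), compound 1 gives 87 ug/mL, the lower of the two numbers in hand. Compound 2 gives 108 ug/mL in this assay; the gap to compound 1 lies within the scatter, so no order between the two can be read from these figures.

Compound 3, `CCOC(=O)c1cnn(-c2nc(-c3ccccc3O)c(C#N)c(=O)n2C)c1N`, differs from compound 1 by hydroxy in place of fluoro on an aromatic carbon. For the measured compounds named here, no pair of measured compounds shows a change of this kind, so the step has no precedent here. A single-atom exchange at this position is expected to move the read-out by no more than the scatter, in no particular direction. The expected step of a 1.0-fold higher number from compound 1 to compound 3 (0.01 log units; within the scatter) is accordingly small. Compound 3 is estimated to give 90 ug/mL in this assay, with a range of 40 ug/mL to 200 ug/mL.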

Compound 3, half-maximal inhibitory concentration: 64 ug/mL
Beside the measured number, compound 3's estimate is 1.4-fold (0.15 log units) above it, and the stated range covers the measured number.
By their numbers in this assay, from the lowest: compounds 3, 1 and 2 (each within the scatter of the next).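

The exchange of 2-fluorophenyl for 2-hydroxyphenyl gives the series its first reading at this position: in this assay the step is a 1.4-fold lower number from compound 1 to compound 3 (0.13 log units; within the scatter) and so cannot be told from repeat measurement. The position therefore tolerates this single-atom exchange on the present figures, even though hydroxy adds a hydrogen-bond donor and a hydrogen-bond acceptor to a place where fluoro counts neither. Nothing at hand bears on the reason for this outcome.

On these data alone, whether an amine or a methoxy group at the same aromatic carbon would give a step beyond the scatter remains open. A single pair also leaves open whether hydroxy in place of fluoro would read the same way if the ethyl ester of compound 1 were replaced by a carboxylic acid.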